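Stereochemistry and a side chain on a bicyclic lactone core

The source may hold more compounds than are shown below. What is called first, only, known or untested is meant among the compounds shown, and "the series" means these compounds.

Compound 1 `C[C@H]1N=C2C[C@H]3C[C@H](C3(C)C)[C@@]2(C)OC1=O`: 27000 nM
Compound 2 `C[C@@H]1N=C2C[C@@H]3C[C@@H](C3(C)C)[C@]2(C)OC1=O`: 145000 nM
Compound 3 `CC1(C)[C@H]2CC3=NCC(=O)O[C@]3(C)[C@@H]1C2`: > 300000 nM

In a functional assay on EL4 cells (Mus musculus) for antiproliferative activity, read by sulforhodamine B assay, with a stated time of 48 h (a higher number here means a weaker inhibitor, a lower number a stronger inhibitor), compound 1 gives 27000 nM, the lowest number among the compounds measured. Its mirror image, compound 2, gives 145000 nM in this assay, and the step of a 5.4-fold higher number from compound 1 to compound 2 (0.73 log units; beyond the scatter) is due to the fact that compounds 1 and 2 differ only in the configuration as drawn alone. Compound 3, which carries hydrogen in place of methyl on a saturated ring carbon, reaches only the limit of > 300000 nM in this assay, at which 1 of the 3 values shown sits, in this assay. The step of an at least 11-fold higher number from compound 1 to compound 3 (1.04 log units; beyond the scatter) therefore marks a large loss.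

Compound 4 `CC(C)(C)OC(=O)CC[C@H]1N=C2C[C@H]3C[C@H](C3(C)C)[C@@]2(C)OC1=O` differs from compound 1 by (tert-butoxycarbonyl)methyl in place of hydrogen on a saturated chain carbon bound to a saturated ring carbon. Neither measured step touches this place: one inverts every stereocentre, the other removes a methyl from a ring carbon. Both show that the core of compound 1 tolerates little change, yet the new group leaves the ring and its configuration intact and only extends a chain.

Within the data shown here, with no step that bears directly on this change, compound 4 is expected to give about 30000 nM in this assay, somewhere between 8000 nM and 120000 nM. The estimated step of a 1.1-fold higher number from compound 1 to compound 4 (0.05 log units; within the scatter) is expected to stay close to the scatter, in either direction.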

Compound 4, half-maximal inhibitory concentration: 51000 nM
The estimate for compound 4 lay 1.7-fold (0.23 log units) below the measured number; low and high end bracket the measured number.
By their numbers in this assay, from the lowest: compounds 1 and 4 (each within the scatter of the next); then compound 2. At a limit, above all of these: compound 3.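

In this assay, the step of a 1.9-fold higher number from compound 1 to compound 4 (0.28 log units; within the scatter) shows that this saturated chain carbon bound to a saturated ring carbon carries (tert-butoxycarbonyl)methyl in place of hydrogen without a difference that can be told from the scatter. That chain carbon is the methyl carbon that compound 3 lacks, so the large step of an at least 11-fold higher number from compound 1 to compound 3 (1.04 log units; beyond the scatter) can now be read with this one: losing the methyl falls beyond the scatter, while building on it does not. Nothing measured in the compounds shown gives a reason for this.

The compounds shown leave open whether the same holds for a free carboxylic acid in place of the tert-butyl ester, for an amine, or for a longer chain on this carbon. They also leave open whether compound 2 would carry (tert-butoxycarbonyl)methyl as well, and whether any such group could bring the number under that of compound 1 at 27000 nM in this series.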